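The source may hold more compounds than are shown below. What is called first, only, known or untested is meant among the compounds shown, and "the series" means these compounds.

In a functional assay on A549 cells (Homo sapiens) for cytotoxicity, read by MTT assay, with a stated time of 48 h (a lower number here means a stronger inhibitor, a higher number a weaker inhibitor), three compounds sharing one core have been measured. Compound 1 `COc1cc(C2=NOC(COc3ccc(-c4nnnn4-c4cc(OC)c(OC)c(OC)c4)cc3N)C2)ccc1O` gives 2010 nM, compound 2 `COc1ccc(C2=NOC(COc3ccc(-c4nnnn4-c4cc(OC)c(OC)c(OC)c4)cc3N)C2)cc1[N+](=O)[O-]` gives 2220 nM, and compound 3 `COc1cc(-n2nnnc2-c2ccc(OCC3CC(c4ccc(C(F)(F)F)cc4)=NO3)c(N)c2)cc(OC)c1OC` gives 1220 nM, so compound 3 stands level with the other two within the scatter. Compound 4 `COc1cc(-n2nnnc2-c2ccc(OCC3CC(c4ccccc4F)=NO3)c(N)c2)cc(OC)c1OC` differs from compound 3 at one place: 2-fluorophenyl in place of 4-(trifluoromethyl)phenyl on a carbon with a double bond to nitrogen. Three measured swaps of the group at this same place bear on it: a 1.1-fold higher number from compound 1 to compound 2 (0.04 log units; within the scatter), a 1.6-fold lower number from compound 1 to compound 3 (0.22 log units; within the scatter) and a 1.8-fold lower number from compound 2 to compound 3 (0.26 log units; within the scatter). All three are small, so no change beyond the scatter is expected in this assay for this new swap, in either direction. The expected step is a 1.2-fold higher number from compound 3 to compound 4 (0.09 log units; within the scatter). For compound 4 the estimated value is 1500 nM, with an expected range of 700 nM to 3200 nM.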

Compound 4, half-maximal inhibitory concentration: 1490 nM
Beside the measured number, compound 4's estimate is 1.0-fold (0.00 log units) above it; low and high end bracket the measured number.
By their numbers in this assay, from the lowest: compounds 3, 4, 1 and 2 (each within the scatter of the next).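

In this assay, replacing the earlier groups with 2-fluorophenyl gives a 1.2-fold higher number from compound 3 to compound 4 (0.09 log units; within the scatter), a 1.5-fold lower number from compound 2 to compound 4 (0.17 log units; within the scatter) and a 1.3-fold lower number from compound 1 to compound 4 (0.13 log units; within the scatter). For the compounds shown here, this position on a carbon with a double bond to nitrogen has now held four differently substituted phenyl rings, and no step among those just given goes beyond the scatter. No available evidence explains this flat result.

On these data alone, all four compounds carry a phenyl ring here, so it remains open whether an amine, a carboxylic acid or a longer alkyl chain at this position would leave the number unchanged.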